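Compound 3: one group changed on a carbonyl carbon

This account rests on a few compounds, and the source may have more. Where it says the series, first, only, none or still open, it means among the compounds named here.

Measured in a physicochemical assay for solubility, with a stated time of 24 h, at pH 2.2; on this read-out higher numbers stand for higher solubility and lower numbers for lower solubility:
- Compound 1 `O=C(NC[C@@H]1[C@H]2CN(C(=O)/C=C/c3cc(Cl)cc(Cl)c3)C[C@@H]12)c1ccc2[nH]c(=O)oc2c1`: < 1 ug/mL, a limit
- Compound 2 `O=C(NC[C@@H]1[C@H]2CN(C(=O)NCc3cc(Cl)cc(Cl)c3)C[C@@H]12)c1ccc2[nH]c(=O)oc2c1`: < 1 ug/mL, a limit

Compound 2 gives no number on this read-out, only the limit < 1 ug/mL.

Compound 3 `CC(OC(=O)N1C[C@@H]2[C@@H](CNC(=O)c3ccc4[nH]c(=O)oc4c3)[C@@H]2C1)c1cc(Cl)cc(Cl)c1` differs from compound 2 at one place: a group of 11 heavy atoms (8 carbon, 1 oxygen, 2 chlorine; one six-membered aromatic ring of carbon only) in place of a group of 10 heavy atoms (7 carbon, 1 nitrogen, 2 chlorine; one six-membered aromatic ring of carbon only), on a carbonyl carbon. Among the compounds with values here, only one measured step bears on this change, and it also replaces a group on a carbonyl carbon. For compound 1 and compound 2 the evidence is the limit of < 1 ug/mL in this assay, at which 2 of the 2 values shown sit. Since that step is a step that the two limits leave unreadable from compound 1 to compound 2, no step beyond the scatter is expected in this assay, in either direction. The estimated change is a step that the limit leaves unreadable from compound 2 to compound 3. Compound 3 is expected at about 0.7 ug/mL, with an estimated range from 0.2 ug/mL to 2 ug/mL, and a further limit rather than a number is the likelier report.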

Compound 3, solubility: < 1 ug/mL
Compound 3: no number, only a limit (the forecaster's own chance of this, stated with the estimate: 80%); the middle value lies beyond the limit too.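

No new step can be read: in this assay compound 1, compound 2 and compound 3 each give only a limit, not a number. As far as these compounds go, whether the three groups on the carbonyl carbon differ at all on this read-out, and in what order, stays open.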